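This account rests on a few compounds, and the source may have more. Where it says the series, first, only, none or still open, it means among the compounds named here.

Compound 1 `CCCCCCCc1ccc(NS(=O)(=O)c2ccc(N3CCNC3=O)cc2)cc1`: > 1000 nM in a functional assay on HT-29 cells (Homo sapiens) for antiproliferative activity, read by sulforhodamine B assay, with a stated time of 48 h (a lower number here means a stronger inhibitor, a higher number a weaker inhibitor), a limit of the assay rather than a number.
Compound 2 `O=C1NCCN1c1ccc(S(=O)(=O)Nc2ccccc2)cc1`: 280 nM in this assay.
Compound 3 `CCCCCCOc1ccc(NS(=O)(=O)c2ccc(N3CCNC3=O)cc2)cc1`: > 1000 nM in this assay, again a limit rather than a number.

Within the data shown here, compound 2 thus stands as the only measured number of the three; the other two sit at the limit of > 1000 nM in this assay, at which 2 of the 3 values shown sit. Compound 4 `COc1cccc(NS(=O)(=O)c2ccc(N3CCNC3=O)cc2)c1` differs from compound 2 by methoxy in place of hydrogen on an aromatic carbon. Among the measured compounds shown here, two measured steps bear on this change: an at least 3.5-fold higher number from compound 2 to compound 3 (0.55 log units; beyond the scatter), and an at least 3.5-fold lower number from compound 1 to compound 2 (0.55 log units; beyond the scatter). Both show that a group added on this ring of compound 2 weakens inhibition, though methoxy is a smaller group than hexyloxy or heptyl. For compound 4 a modest rise in the number is therefore expected, a 2.1-fold higher number from compound 2 to compound 4 (0.33 log units; beyond the scatter). Compound 4 is estimated at 600 nM, within 250 nM to 2500 nM.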

Compound 4, half-maximal inhibitory concentration: 120 nM
The estimate for compound 4 lay 5.0-fold (0.70 log units) above the measured number; the whole stated range lies above it.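

In this assay, the change from phenyl to 3-methoxyphenyl gives a 2.3-fold lower number from compound 2 to compound 4 (0.37 log units; beyond the scatter) and so shows that a group added to this ring does not always weaken inhibition. Here the added methoxy sits meta to a large group and brings a gain, which no earlier step showed. Compound 1 and compound 3 each give only a limit, not a number: the limit of > 1000 nM in this assay, at which 2 of the 4 values shown sit.

From the compounds shown here alone, whether an amine, a carboxylic acid or a longer chain such as ethoxy at this same place would keep the gain remains open.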